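The compounds below may be only part of what the source reports. "The series", "measured", "known", "first", "only" and "open" are said of these compounds alone.

Measured so far in a physicochemical assay for solubility, with a stated time of 18 h, at pH 7.4; a higher number here means a more soluble compound, a lower number a less soluble compound (solubility; a higher number means a more soluble compound, a lower number a less soluble one):

Compound 1 `c1ccc(Oc2ccc3c(NCCCNCc4ccco4)ccnc3c2)cc1` — 14500 nM
Compound 2 `COc1cccc(Oc2ccc3c(NCCCNCc4cc(F)ccc4OC)ccnc3c2)c1` — 14500 nM
Compound 3 `COc1cccc(CNCCCNc2ccnc3cc(Oc4ccccc4)ccc23)c1O` — 14500 nM

All three compounds share one core and differ in the group carried on a saturated chain carbon bound to an amine nitrogen. In this assay compound 1 stands level with compounds 2 and 3 at the digits shown: its nearest neighbour is compound 2 and its furthest is compound 3, and neither gap reaches beyond the scatter of the measurement.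

Among the measured compounds shown here, the one step that can be followed between measured compounds is no change at the digits printed from compound 1 to compound 3 (within the scatter), a change of 2-hydroxy-3-methoxyphenyl in place of furan-2-yl on that chain carbon. It left the solubility where it was.

Compound 4 `c1ccc(Cc2ccc3c(NCCCNCc4ccco4)ccnc3c2)cc1` has not been measured. It differs from compound 1 in another part of the molecule: benzyl in place of phenoxy on an aromatic carbon. For the measured compounds named here, none of the measured steps touches this position, so there is no direct guide. Going by the values given here, the only evidence is that the three measured compounds sit together, and this gives no reason to expect movement.

Compound 4 is therefore expected to give about 14500 nM in this assay, within a range of 7000 nM to 29000 nM. The step expected from compound 1 to compound 4 is no change at the digits printed from compound 1 to compound 4 (within the scatter), that is, none beyond the scatter.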

Compound 4, solubility: 4200 nM
Beside the measured number, compound 4's estimate is 3.5-fold (0.54 log units) above it, outside the stated range (below it).
By their numbers in this assay, from the lowest: compound 4; then compounds 1, 2 and 3 (each within the scatter of the next).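

In this assay, among the compounds shown here, the exchange of phenoxy for benzyl on the aromatic carbon gives a 3.5-fold lower number from compound 1 to compound 4 (0.54 log units; beyond the scatter) and so moves the number beyond the scatter, which the one step that could be followed on the chain carbon did not do. This marks the aromatic carbon as a place where solubility can respond, even though the change is small on paper: both groups have the same count of heavy atoms and one aromatic ring of carbon only, while phenoxy holds an oxygen where benzyl holds a carbon and so carries a hydrogen-bond acceptor that benzyl lacks. Nothing available here shows what lies behind the drop, so neither that difference nor any other can be named as its source.

As far as these compounds go, it remains open whether the same exchange would lower the number to a similar extent with 2-hydroxy-3-methoxyphenyl in place of furan-2-yl on the chain carbon. Also open, from the compounds shown here alone, is how other groups on this aromatic carbon would read, such as an amine, a carboxylic acid or the longer phenethyl chain.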